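Truncating the amino-acid side chain: compound 2 to compound 3

This account rests on a few compounds, and the source may have more. Where it says the series, first, only, none or still open, it means among the compounds named here.

Among the compounds with values here, compound 2 `C[C@@H](O)[C@H](NC(=O)CN(c1ncnc2c1ncn2C1CCCCO1)C1CC1)C(=O)OCc1ccccc1` holds the lower of the two numbers measured so far in a functional assay on the whole organism (Tail, strain ICR) with Mus musculus as the target, in the tail flick test, with a stated time of 30 min, at a dose of 25 umol/kg by the oral route; a lower number here means a weaker effect, a higher number a stronger effect of the compound at the dose given: compound 2 gives 23.6%, whereas compound 1 `NC(=O)CC[C@H](NC(=O)CN(c1ncnc2c1ncn2C1CCCCO1)C1CC1)C(=O)OCc1ccccc1` gives 47%. Within the data shown here, the single measured step, a number 23.4 percentage points lower from compound 1 to compound 2 (beyond the scatter), joins these two and is the only change at this position recorded so far.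

Compound 3 `C[C@H](NC(=O)CN(c1ncnc2c1ncn2C1CCCCO1)C1CC1)C(=O)OCc1ccccc1` has not been measured. It differs from compound 2 by methyl in place of 1-hydroxyethyl on a saturated chain carbon bound to an amide-type nitrogen and a carbonyl carbon. Among the measured compounds shown here, no measured step removes a hydroxyl from this carbon, so the change from compound 1 to compound 2 bears on the question only indirectly: it shows that exchanging the group on this saturated chain carbon can move the read-out by a modest amount, with the smaller group giving the lower number. On that slender basis a further modest fall, or a step within the scatter, is expected rather than a rise. The step expected is a number 8.6 percentage points lower from compound 2 to compound 3 (within the scatter). For compound 3 the estimate is 15%, with an expected range from 2% to 38%.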

Compound 3, a percentage reported as activity, at one dose (the size of the read-out at that dose, not a potency): 55.9%
Compound 3: middle estimate off by 40.9 percentage points, on the low side; measured number above the stated range.
By their numbers in this assay, from the lowest: compound 2; then compounds 1 and 3 (each within the scatter of the next).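

In this assay, replacing 1-hydroxyethyl with methyl on this saturated chain carbon gives a number 32.3 percentage points higher from compound 2 to compound 3 (beyond the scatter) and so sets compound 2 apart, which means that a shorter group at this carbon does not by itself bring a lower number. The other new comparison, a number 8.9 percentage points higher from compound 1 to compound 3 (within the scatter) for the exchange of the longer 2-carbamoylethyl side chain for methyl, shows that these two groups cannot be told apart in this assay, even though they differ widely in length. Across the three compounds, then, the length of the group does not order the read-out, compound 2 being the one that goes against such a trend, and nothing measured here explains why.

The compounds shown do not separate the hydroxyl of 1-hydroxyethyl from its branched carbon chain, a question that an isopropyl or a hydroxymethyl group on this carbon would bear on directly. As far as these compounds go, how an amine or a carboxylic acid at the end of a longer chain on this carbon would compare with 2-carbamoylethyl also stays open.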